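Extending an Alkyl Chain and Cytotoxicity Toward HeLa Cells

The compounds below may be only part of what the source reports. "The series", "measured", "known", "first", "only" and "open" are said of these compounds alone.

Of the compounds shown here, three have been tested in a functional assay on HeLa cells (Homo sapiens) for cytotoxicity, read by MTT assay, with a stated time of 24 h; on this read-out lower numbers stand for stronger inhibition and higher numbers for weaker inhibition. Compound 1 `CCCCCCCCCCn1cc(-c2nc3ccccc3cc2CCCC)nn1` returns only a limit, > 100 ug/mL. Compound 3 `CCCCCc1cc2ccccc2nc1-c1cn(CCC(F)(F)C(F)(F)C(F)(F)C(F)(F)C(F)(F)C(F)(F)C(F)(F)C(F)(F)F)nn1` likewise gives a limit, > 100 ug/mL. Compound 2 `Cc1cc2ccccc2nc1-c1cn(-c2ccc(F)cc2)nn1` also stands at a limit, > 100 ug/mL. All three values therefore sit at the limit of > 100 ug/mL in this assay, at which 3 of the 3 values shown sit, and none can be ranked against another. Compound 4 `CCCCc1cc2ccccc2nc1-c1cn(-c2ccc(F)cc2)nn1` remains to be measured; it differs from compound 2 by propyl in place of hydrogen on a saturated chain carbon bound to an aromatic carbon. For the measured compounds named here, no measured pair differs in a single place, so there is no step to lean on. Because the measured values all rest at the limit of > 100 ug/mL in this assay, at which 3 of the 3 values shown sit, the author expects the step of a number no higher from compound 2 to compound 4 (the limit leaves the size open) to amount to no shift beyond the scatter, with a limit the most likely outcome. Compound 4 is thus estimated at 100 ug/mL, between 50 ug/mL and 200 ug/mL.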

Compound 4, half-maximal inhibitory concentration: > 100 ug/mL
Compound 4 was reported as a limit (the forecaster's own chance of this, stated with the estimate: 80%); the middle value sits exactly at the limit.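

No step can be read from compound 2 to compound 4, since both are reported only as limits in this assay: the limit of > 100 ug/mL in this assay, at which 4 of the 4 values shown sit.

The compounds shown leave open whether any group on the shared core gives a measurable number in this assay.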